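Cyano in place of fluoro on compound 2

The compounds below may be only part of what the source reports. "The series", "measured", "known", "first", "only" and "open" are said of these compounds alone.

Of the compounds shown here, two with a shared core have been measured so far in a functional assay on SF-295 cells (Homo sapiens) for antiproliferative activity, read by sulforhodamine B assay, with a stated time of 72 h (on this read-out higher numbers stand for weaker inhibition and lower numbers for stronger inhibition), on these cells. Compound 1 (`O=C1CS/C(=N/Nc2nncc3ccccc23)N1c1ccccc1`) gives 4.6 nM and compound 2 (`Fc1ccc(Nc2nncc3ccccc23)cc1`) gives 0.43 nM as the lower of the two numbers. That gap lies beyond the usual scatter of repeated measurements, so compound 2 is the stronger inhibitor of this pair.

Compound 3 (`N#Cc1ccc(Nc2nncc3ccccc23)cc1`) still awaits its measurement. It differs from compound 2 in one place: cyano in place of fluoro on an aromatic carbon, para to a large group (cyano in place of fluoro on an aromatic carbon).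

Going by the values given here, no measured pair yet shows what this swap does, so compound 2 at 0.43 nM is the only close reference. In this assay the estimated step (a 1.4-fold higher number from compound 2 to compound 3 (0.14 log units; within the scatter)) is a slight rise in the number, meaning slightly weaker inhibition, and it is expected to stay within the scatter. Among the compounds with values here, the range must stay wide: only two measured compounds stand behind it. For compound 3 the expected value is 0.6 nM with an estimated range from 0.15 nM to 3 nM in this test.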

Compound 3, half-maximal inhibitory concentration: 0.32 nM
Beside the measured number, compound 3's estimate is 1.9-fold (0.27 log units) above it; the measured number falls inside the stated range.
By their numbers in this assay, from the lowest: compounds 3 and 2 (each within the scatter of the next); then compound 1.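

In this assay, putting cyano in place of fluoro on an aromatic carbon, para to a large group, gives a 1.3-fold lower number from compound 2 to compound 3 (0.13 log units; within the scatter), so this read-out cannot tell compound 2 and compound 3 apart. Going by these compounds alone, this is the first measured pair at this position, and it shows that the position can carry cyano, with two heavy atoms and one hydrogen-bond acceptor, as well as fluoro, with one heavy atom and no hydrogen-bond acceptor, without the number leaving the scatter. No measurement of any property of these two groups bears on this result.

From the compounds shown here alone, one pair cannot show how far this tolerance reaches, so it remains open how an amine, a carboxylic acid or a longer chain in the same place would read on these cells. Going by these compounds, it also remains open whether the same swap would give a similarly small step on a different compound, or in cells other than those used here.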